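Ring Opening at the Aromatic Nitrogen of Compound 1

The source may report more compounds than this note shows. Statements on the series, on what has been measured and on what is new or still open speak of the compounds shown alone.

Compound 1, `SC1=NNCC(n2c(-c3ccco3)nc3ccccc32)=N1`: 62100 nM
Compound 2, `O=C(Cn1c(-c2ccco2)nc2ccccc21)N/N=C/c1ccccc1Cl`: 26000 nM
Compound 3, `NNC(=O)CSc1nnc(Cn2c(-c3ccco3)nc3ccccc32)s1`: 26900 nM

Of the compounds shown here, three sharing the same core have been tested in a functional assay on HepG2 cells (Homo sapiens) for cytotoxicity, read by sulforhodamine B assay, with a stated time of 48 h; a lower number here means a stronger inhibitor, a higher number a weaker inhibitor. Compound 1 gives the highest of the three numbers, at 62100 nM. Its nearest neighbour is compound 3, whose value of 26900 nM lies beyond the scatter below it, and compound 2, at 26000 nM, stands slightly further away in the same direction. All three are weak inhibitors, and the spread among them is narrow.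

Compound 4, `N=C(Cn1c(-c2ccco2)nc2ccccc21)NN`, has not yet been measured in this assay. It differs from compound 1 in one place: a group of 5 heavy atoms (2 carbon, 3 nitrogen; no ring) in place of a group of 7 heavy atoms (3 carbon, 3 nitrogen, 1 sulfur; one six-membered non-aromatic ring with 3 hetero atoms), on an aromatic nitrogen. The group that leaves carries the ring with the sulfur; the group that enters is an open chain with one more hydrogen-bond donor and one fewer acceptor.

Going by the values given here, no step between measured compounds resembles this change, so there is little to lean on. Given how closely the three measured values cluster, the step from compound 1 to compound 4 is expected to be small, with the direction uncertain; the estimate is a 1.6-fold lower number from compound 1 to compound 4 (0.19 log units; within the scatter). Compound 4 is therefore expected to give about 40000 nM, within a range from 12000 nM to 130000 nM.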

Compound 4, half-maximal inhibitory concentration: 74500 nM
Compound 4: middle estimate off by 1.9-fold (0.27 log units), on the low side; low and high end bracket the measured number.
By their numbers in this assay, from the lowest: compounds 2 and 3 (each within the scatter of the next); then compounds 1 and 4 (each within the scatter of the next).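

In this assay, putting the open chain in place of the six-membered non-aromatic ring with 3 hetero atoms on the aromatic nitrogen gives a 1.2-fold higher number from compound 1 to compound 4 (0.08 log units; within the scatter), so the two groups cannot be told apart at this position. This is the first measured step at this position among the compounds shown, and it shows that the ring can be opened and the sulfur removed with no difference beyond the scatter, even though the count of hydrogen-bond donors and acceptors shifts with the change. No measurement shown here explains why the two groups read alike.

The step changes the ring, the sulfur and the chain together, so the compounds shown leave open whether any one of these matters alone, or whether the ring and the sulfur have separate effects that cancel. They also leave open whether a carboxylic acid, a simple amine or a longer chain on the same aromatic nitrogen would give a number beyond the scatter of these two.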